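Swapping a Diethylamino Tail for Piperidine: Expected Cytotoxicity

The compounds below may be only part of what the source reports. "The series", "measured", "known", "first", "only" and "open" are said of these compounds alone.

Compound 1 `CCN(CC)CC(=O)Nc1ccc(-c2nc3cc(C(F)(F)F)ccc3n2C)cc1` was tested in an ADME assay on BHK cells (Mesocricetus auratus) for cytotoxicity, read by MTT assay, with a stated time of 96 h (a lower number here means that less compound is tolerated, a higher number that more compound is tolerated), and gives 16000 nM. Of the two true numbers in hand, this is the lower one, and its nearest neighbour is compound 2 `CCN(CC)CC(=O)Nc1ccc(-c2nc3cc(C(F)(F)F)ccc3[nH]2)cc1`, which gives 23000 nM. The step of a 1.4-fold higher number from compound 1 to compound 2 (0.16 log units; within the scatter) does not rise above the ordinary spread of repeated measurements. Compound 3 `O=[N+]([O-])c1ccc(-c2nc3cc(C(F)(F)F)ccc3n2C2CCCCC2)cc1` reaches only the limit of the method, > 100000 nM, so no exact number is known for it. That value sits at the limit of > 100000 nM in this assay, at which 1 of the 3 values shown sits.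

Compound 4 `Cn1c(-c2ccc(NC(=O)CN3CCCCC3)cc2)nc2cc(C(F)(F)F)ccc21` has not yet been measured. It differs from compound 1 in one place: piperidin-1-yl in place of diethylamino on a saturated chain carbon bound to a carbonyl carbon. Among the measured compounds shown here, the only measured step, from compound 1 to compound 2, alters a different part of the molecule and stays within the scatter, so no measured step speaks directly to the present change. Nothing in the numbers at hand points to a move in either direction beyond the scatter.

Compound 4 is therefore expected to give about 18000 nM, with a likely range from 8000 nM to 40000 nM. This estimate amounts to an expected 1.1-fold higher number from compound 1 to compound 4 (0.05 log units; within the scatter), a step judged to lie within the scatter.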

Compound 4, half-maximal cytotoxic concentration: > 100000 nM
Compound 4: only a limit was reported; the forecaster's own chance of this, stated with the estimate: 10%; at least 5.5-fold (0.74 log units) between middle value and limit.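

In this assay compound 4 gives > 100000 nM, which is a limit of the assay and not a number, so its true value stays unknown: the limit of > 100000 nM in this assay, at which 2 of the 4 values shown sit.

Even so, replacing diethylamino with piperidin-1-yl on a saturated chain carbon bound to a carbonyl carbon gives an at least 6.2-fold higher number from compound 1 to compound 4 (0.79 log units; beyond the scatter), which shows that the amine at this position can change how much compound the cells tolerate, something the only earlier step, a 1.4-fold higher number from compound 1 to compound 2 (0.16 log units; within the scatter), could not show, as it alters a different place and stays within the scatter. The two groups have the same hydrogen-bond counts and no net charge, and they differ in that piperidin-1-yl forms a ring and has one more carbon, so the change lies in the shape and size of the amine rather than in those counted features.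

The compounds shown leave open whether the ring itself or the extra carbon goes with the higher number, and how large the step really is. A smaller pyrrolidine ring or a morpholine ring in the same place would help to separate these possibilities, provided its value fell short of the limit.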